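From nitro to chloro on the aromatic ring

The source may hold more compounds than are shown below. What is called first, only, known or untested is meant among the compounds shown, and "the series" means these compounds.

Values in a functional assay on cells (Homo sapiens) for cytotoxicity, read by MTT assay, with a stated time of 24 h; on this read-out lower numbers stand for stronger inhibition and higher numbers for weaker inhibition:
Compound 1 `CCCCCCCCCCCCCCNC(=O)[C@H](CO)/N=C/c1ccccc1OC`: 12500 nM
Compound 2 `CCCCCCCCCCCCCCNC(=O)[C@H](CO)/N=C/c1ccccc1Cl`: 10300 nM
Compound 3 `CCCCCCCCCCCCCCNC(=O)[C@H](CO)/N=C/c1cccc([N+](=O)[O-])c1`: 104000 nM

Compound 3 stands highest of the three, at 104000 nM. Compound 4 `CCCCCCCCCCCCCCNC(=O)[C@H](CO)/N=C/c1cccc(Cl)c1`, not yet measured, has chloro in place of nitro on an aromatic carbon. Going by the values given here, two measured steps bear most directly on this change: a 10-fold higher number from compound 2 to compound 3 (1.00 log units; beyond the scatter) and an 8.3-fold higher number from compound 1 to compound 3 (0.92 log units; beyond the scatter). A third, a 1.2-fold lower number from compound 1 to compound 2 (0.08 log units; within the scatter), is small. Among the compounds with values here, compound 2 also carries chloro, but no measured pair isolates nitro against chloro on the same carbon. In this assay, a step of nearly similar size towards lower numbers is therefore expected: a 6.9-fold lower number from compound 3 to compound 4 (0.84 log units; beyond the scatter). Compound 4 is estimated at 15000 nM, with an expected range of 6000 nM to 50000 nM.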

Compound 4, half-maximal inhibitory concentration: 24100 nM
The estimate for compound 4 lay 1.6-fold (0.21 log units) below the measured number, and the stated range covers the measured number.
By their numbers in this assay, from the lowest: compounds 2, 1 and 4 (each within the scatter of the next, the first and the last beyond it); then compound 3.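

In this assay, going by these compounds alone, chloro in place of nitro on this aromatic carbon gives a 4.3-fold lower number from compound 3 to compound 4 (0.64 log units; beyond the scatter), the first direct reading of this exchange, and it leaves compound 4 still short of the ortho-free comparison with nothing further implied. Moving the chloro, 3-chlorophenyl in place of 2-chlorophenyl gives a 2.3-fold higher number from compound 2 to compound 4 (0.37 log units; beyond the scatter), so the place of the chloro also counts, whereas 3-chlorophenyl in place of 2-methoxyphenyl gives a 1.9-fold higher number from compound 1 to compound 4 (0.29 log units; within the scatter). Nothing available explains these steps.

The compounds shown leave open how an amine or a carboxylic acid on this carbon would compare with chloro and nitro. They also leave open whether these steps would hold with a longer chain.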